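The source may report more compounds than this note shows. Statements on the series, on what has been measured and on what is new or still open speak of the compounds shown alone.

In an ADME assay on BJ cells (Homo sapiens) for cytotoxicity, with a stated time of 72 h (a higher number here means that more compound is needed for the effect, a lower number that less compound is needed), the compounds measured so far read as follows, each value being a limit and not a number:

Compound 1 (`CCc1ccc(-c2nc3c(c(C)nn3-c3ccccc3)c(-c3ccccc3[N+](=O)[O-])c2C#N)cc1`) gives > 20000 nM as a limit.
Compound 2 (`CCc1ccc(-c2nc3c(c(C)nn3-c3ccccc3)c(-c3ccccc3I)c2C#N)cc1`) gives > 20000 nM as a limit.
Compound 3 (`CCc1ccc(-c2nc3c(c(C)nn3-c3ccccc3)c(-c3ccccc3Br)c2C#N)cc1`) gives > 20000 nM as a limit.

Compound 3 has no number of its own and stands with the others at the limit of > 20000 nM in this assay, at which 3 of the 3 values shown sit, in this series. Compound 4 (`CCc1ccc(-c2nc3c(c(C)nn3-c3ccccc3)c(-c3ccccc3Cl)c2C#N)cc1`) differs from it by chloro in place of bromo on an aromatic carbon and the change is chloro in place of bromo on an aromatic carbon, ortho to a large group.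

Three measured swaps bear on this change. For the measured compounds named here, the first is a step that the two limits leave unreadable from compound 2 to compound 3 and the second is a step that the two limits leave unreadable from compound 1 to compound 3 while the third is a step that the two limits leave unreadable from compound 1 to compound 2 and so none of them gives a size. Going by the values given here, the only guide is that all three compounds share one limit, so no step beyond the scatter is expected in this assay here. The estimated change is a step that the limit leaves unreadable from compound 3 to compound 4 in size. The expected value of compound 4 is 25000 nM within an estimated range of 14000 nM to 50000 nM and it may well prove to be only a limit.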

Compound 4, half-maximal effective concentration: > 20000 nM
Compound 4 was reported as a limit (the forecaster's own chance of this, stated with the estimate: 90%); the middle value lies beyond the limit too.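

Compound 4, like compound 1, compound 2 and compound 3, is reported only as a limit, so no step among these compounds can be read in this assay: the limit of > 20000 nM in this assay, at which 4 of the 4 values shown sit. The compounds shown leave open whether swapping the nitro, iodo, bromo and chloro groups changes the true values at all.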